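The source may hold more compounds than are shown below. What is called first, only, known or untested is meant among the compounds shown, and "the series" means these compounds.

Measured so far in a functional assay on the whole organism for inhibition, with Cavia porcellus as the target; a lower number here means that less compound is needed, a higher number that more compound is needed for the effect:
compound 1 `COc1ccccc1OCC1SCCN1C(=O)CSC(C)=O`: 26 mg/kg
compound 2 `CC(=O)SCC(=O)N1CCSC1COc1ccccc1O`: 60 mg/kg

Compound 1 holds the lower of the two numbers in this assay; its nearest neighbour is compound 2, with a 2.3-fold higher number from compound 1 to compound 2 (0.36 log units; beyond the scatter) for hydrogen in place of methyl on an oxygen on an aromatic ring.

Compound 3 `COc1ccccc1OC[C@@H]1SCCN1C(=O)CSC(C)=O` differs from compound 1 only thus: the two compounds have the same atoms and bonds; at least one stereo element is drawn with a configuration in one of them and without one in the other: 1 of 1 stereo elements differ; a stereocentre at a saturated ring carbon is drawn without a configuration in compound 1 and S in compound 3. Among the measured compounds shown here, no measured step concerns a drawn configuration, so the one step known, at the methyl on oxygen, does not bear on this change. A step of no size beyond the scatter is therefore expected. Compound 3 is estimated at 22 mg/kg (range 10 mg/kg to 50 mg/kg), an expected step of a 1.2-fold lower number from compound 1 to compound 3 (0.07 log units; within the scatter).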

Compound 3, dose for half-maximal effect: 52 mg/kg
Estimate against measurement, compound 3: 2.4-fold (0.37 log units) below, and the stated range ends below it.
By their numbers in this assay, from the lowest: compounds 1, 3 and 2 (each within the scatter of the next, the first and the last beyond it).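

In this assay, among the compounds shown here, this is the first reading on a drawn configuration (a 2.0-fold higher number from compound 1 to compound 3 (0.30 log units; within the scatter)). The ring carbon therefore carries a defined S configuration with no step beyond the scatter. The comparison remains one between a defined drawing and an undefined one: the fact that one of compounds 1 and 3 is drawn with a defined configuration and the other without, at the place where they differ

Open, going by these compounds, is how the R form reads against the S form, and whether hydrogen in place of methyl on an oxygen on an aromatic ring gives the same step with the configuration drawn. Also open, on these data alone, is how an amine or a carboxylic acid on the aromatic ring would read.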